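Amide-nitrogen variations on a shared core

A few compounds are considered here, and "the series" means these few. Any claim that something is new, unique, unknown or untested is made for them only; others in the source may bear on it.

Measured so far:
Compound 1 `COc1ccc2nc(C)cc(OCC(=O)NCc3cc(C)cc(C)c3)c2c1`: 5.25
Compound 2 `COc1ccc2nc(C)cc(OCC(=O)Nc3cc(C)ccc3C)c2c1`: 5.05
Compound 3 `COc1ccc2nc(C)cc(OCC(=O)Nc3cc(F)cc(F)c3)c2c1`: 5.13

In a physicochemical assay for lipophilicity, read by HPLC, in phosphate buffer, measured as chromatographic lipophilicity, at pH 7.4 (a higher number here means a more lipophilic compound, a lower number a more polar compound), compound 3 stands second highest of the three numbers, though all three lie within the scatter of one another: compound 2 is nearest (a number 0.08 log units higher from compound 2 to compound 3 (within the scatter)) and compound 1 furthest (a number 0.12 log units lower from compound 1 to compound 3 (within the scatter)). Compound 4 `COc1ccc2nc(C)cc(OCC(=O)Nc3nc(C)c(C)s3)c2c1` differs from compound 3 by 4,5-dimethyl-1,3-thiazol-2-yl in place of 3,5-difluorophenyl on an amide-type nitrogen. Going by the values given here, the measured steps, a number 0.20 log units lower from compound 1 to compound 2 (within the scatter) and a number 0.12 log units lower from compound 1 to compound 3 (within the scatter), exchange one carbocyclic group for another and stay within the scatter; no measured step introduces a five-membered aromatic ring with 2 hetero atoms, so they bear only loosely on this change. A small downward step in this assay is nonetheless expected, a number 0.43 log units lower from compound 3 to compound 4 (beyond the scatter), just beyond the scatter. Compound 4 is estimated at 4.7, range 4.3 to 5.1.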

Compound 4, distribution coefficient: 4.24
Compound 4: the middle estimate sits 0.46 log units above what was measured; measured number outside the range, below it.
By their numbers in this assay, from the lowest: compound 4; then compounds 2, 3 and 1 (each within the scatter of the next).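

In this assay, this amide-type nitrogen position can shift the number beyond the scatter: 4,5-dimethyl-1,3-thiazol-2-yl gives a number 0.89 log units lower from compound 3 to compound 4 (beyond the scatter), a number 0.81 log units lower from compound 2 to compound 4 (beyond the scatter) and a number 1.01 log units lower from compound 1 to compound 4 (beyond the scatter). The three carbocyclic groups, by contrast, lie within the scatter of one another, leaving compound 4 the lowest of the four. Nothing at hand accounts for this drop.

Still open, from the compounds shown here alone, is whether the drop follows the ring itself or its two methyl groups. Equally open, going by these compounds, is how an unsubstituted 1,3-thiazol-2-yl or a pyridin-2-yl would read at this nitrogen.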